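This account rests on a few compounds, and the source may have more. Where it says the series, first, only, none or still open, it means among the compounds named here.

Within the data shown here, in a functional assay on HUVEC cells (Homo sapiens) for inhibition (a lower number here means a stronger inhibitor, a higher number a weaker inhibitor), two compounds have numbers so far. Compound 1 (`CN(c1ccc(NS(=O)(=O)Cc2ccccc2)cc1)c1ccnc(Nc2cccc(CS(C)(=O)=O)c2)n1`) gives 350 nM, the higher of the two, while compound 2 (`CN(c1ccc(NC(=O)Nc2cc(C(F)(F)F)ccc2F)cc1)c1ccnc(Nc2ccc(S(N)(=O)=O)cc2)n1`) gives 8 nM, a gap well beyond the scatter of repeated measurements. Compound 1 is therefore the weaker inhibitor of this pair.

Compound 3 (`CN(C)CCNC(=O)Nc1ccc(N(C)c2ccnc(Nc3cccc(CS(C)(=O)=O)c3)n2)cc1`) has yet to be measured in this assay. It keeps the core of compound 1 and changes it in one place: (2-(dimethylamino)ethyl)carbamoyl in place of benzylsulfonyl on a nitrogen on an aromatic ring. In plain terms, (2-(dimethylamino)ethyl)carbamoyl stands in place of benzylsulfonyl on a nitrogen on an aromatic ring.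

Among the measured compounds shown here, no measured pair isolates this change, so any expectation for it remains loose. Compound 2, at 8 nM, shows that much lower numbers occur in this small set, and a moderate fall is therefore expected rather than a rise. The expected size of the change is a 2.3-fold lower number from compound 1 to compound 3 (0.37 log units; beyond the scatter). The estimated value for compound 3 is 150 nM, with an expected range from 30 nM to 700 nM.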

Compound 3, half-maximal inhibitory concentration: 530 nM
Beside the measured number, compound 3's estimate is 3.5-fold (0.55 log units) below it; measured number inside the range.
By their numbers in this assay, from the lowest: compound 2; then compounds 1 and 3 (each within the scatter of the next).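

In this assay, the exchange of benzylsulfonyl for (2-(dimethylamino)ethyl)carbamoyl on a nitrogen on an aromatic ring is read as a 1.5-fold higher number from compound 1 to compound 3 (0.18 log units; within the scatter) and gives the first direct view of this position. With the rest of compound 1 held constant, a group with a six-membered aromatic ring of carbon only and a group with no ring give numbers that cannot be told apart, so this ring is not required to keep the number in this range. No measurement on hand accounts for this similarity.

The compounds shown leave open whether another group on this nitrogen, such as an acetyl group or a longer chain ending in a morpholine ring, would shift the number beyond the scatter. Compound 2 differs from compound 1 in more than one place, so its number cannot be assigned to any single part of its structure.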